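Aryl substituent swap on the shared core: methoxy to fluoro

The source may report more compounds than this note shows. Statements on the series, on what has been measured and on what is new or still open speak of the compounds shown alone.

The pair measured so far shares one core and differs only on the pendant phenyl ring. Compound 1 `c1ccc(-c2cn3ccnc3c(-c3ccc4ncn(C5CCCCC5)c4c3)n2)cc1` carries that ring unsubstituted; in a functional assay on SW-620 cells (Homo sapiens) for inhibition, read by sulforhodamine B assay, with a stated time of 48 h, tested at 10 uM (a lower number here means less inhibition, a higher number more inhibition at the concentration tested (going by the name of the read-out)), compound 1 gives 9.15%. Compound 2 `COc1ccc(-c2cn3ccnc3c(-c3ccc4ncn(C5CCCCC5)c4c3)n2)cc1` carries a methoxy on an aromatic carbon of that ring, and in this assay compound 2 gives 77.8%. For the measured compounds named here, the single step between them, a number 68.7 percentage points higher from compound 1 to compound 2 (beyond the scatter), is the only step in the set. Compound 2 thus stands highest of the two numbers, with compound 1 as its nearest neighbour far below it.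

Compound 3 `Fc1ccc(-c2cn3ccnc3c(-c3ccc4ncn(C5CCCCC5)c4c3)n2)cc1` is the next variant: fluoro in place of methoxy on an aromatic carbon. Going by the values given here, the one step that bears on it is the methoxy-for-hydrogen step, which was large. Fluoro brings in no acceptor, as methoxy does, so the new substituent is taken as closer to the unsubstituted case than to the methoxy case, and a fall beyond the scatter is expected, a number 47.8 percentage points lower from compound 2 to compound 3 (beyond the scatter), though with wide uncertainty since only one step is known. For compound 3 the estimated value in this assay is 30%, with a range from 5% to 65%.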

Compound 3, a percentage reported as inhibition, at one concentration (the size of the read-out at that concentration, not a potency): 8.38%
For compound 3 the middle estimate is 21.6 percentage points above the measured one; measured number inside the range.
By their numbers in this assay, from the lowest: compounds 3 and 1 (each within the scatter of the next); then compound 2.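

At this position, para to a large group, a number 69.4 percentage points lower from compound 2 to compound 3 (beyond the scatter), so the high reading in this assay does not carry over from methoxy to fluoro. Fluoro also gives no separation from hydrogen, with a number 0.8 percentage points lower from compound 1 to compound 3 (within the scatter), so the earlier pair's contrast between methoxy and hydrogen now reads as a contrast between methoxy and two substituents that cannot be told apart, and among these three compounds only compound 2, with its 4-methoxyphenyl, stands apart from the others. Nothing available explains why methoxy and fluoro part so widely at this position.

As far as these compounds go, with only hydrogen, fluoro and methoxy at this place, it remains open whether the high reading depends on the oxygen, on the methyl beyond it, or on the whole methoxy group, and a hydroxy, an ethoxy or a dimethylamino group at the same place would bear on that question. Also open, from the compounds shown here alone, is whether the gap between 4-methoxyphenyl and 4-fluorophenyl persists when the cyclohexyl on the shared core gives way to another group, such as a cyclopentyl or a longer alkyl chain.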